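Swapping Methyl for Methoxy on a Benzyl Triazole

The source may hold more compounds than are shown below. What is called first, only, known or untested is meant among the compounds shown, and "the series" means these compounds.

Three compounds sharing one core were tested in a functional assay on MGC-803 cells (Homo sapiens) for antiproliferative activity, read by MTT assay, with a stated time of 48 h; a higher number here means a weaker inhibitor, a lower number a stronger inhibitor. Compound 1 `Clc1ccc(Cn2cc(CSc3nnc(-c4ccccc4)c(-c4ccccc4)n3)nn2)cc1` gives 13200 nM. Compound 2 `Cc1ccc(Cn2cc(CSc3nnc(-c4ccccc4)c(-c4ccccc4)n3)nn2)cc1` gives 34800 nM, and compound 3 `c1ccc(Cn2cc(Cc3nnc(-c4ccccc4)c(-c4ccccc4)n3)nn2)cc1` gives 11400 nM. Among these three numbers compound 2 stands highest, meaning it is the weakest inhibitor of the set: the step of a 2.6-fold higher number from compound 1 to compound 2 (0.42 log units; beyond the scatter) is modest but beyond the scatter, and the value of compound 3 lies lower still than that of compound 2.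

Compound 4 `COc1ccc(Cn2cc(CSc3nnc(-c4ccccc4)c(-c4ccccc4)n3)nn2)cc1` differs from compound 2 in one place: methoxy in place of methyl on an aromatic carbon. Among the measured compounds shown here, only one measured step touches this position of the benzyl ring, namely a 2.6-fold higher number from compound 1 to compound 2 (0.42 log units; beyond the scatter), where chloro was replaced by methyl. For the measured compounds named here, no measured pair shows what methoxy does at this position, so the direction of the change cannot be read from the data. Given that the single change known at this site moved the number by a modest amount, a step of similar size or none beyond the scatter is expected for a 1.4-fold lower number from compound 2 to compound 4 (0.14 log units; within the scatter) in this assay. Compound 4 is therefore estimated to give 25000 nM, with a plausible range from 8000 nM to 70000 nM.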

Compound 4, half-maximal inhibitory concentration: 22700 nM
For compound 4 the middle estimate is 1.1-fold (0.04 log units) above the measured one, within the range that was stated.
By their numbers in this assay, from the lowest: compounds 3, 1, 4 and 2 (each within the scatter of the next, the first and the last beyond it).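

In this assay methoxy on this aromatic carbon gives a 1.5-fold lower number from compound 2 to compound 4 (0.19 log units; within the scatter) when it replaces methyl and a 1.7-fold higher number from compound 1 to compound 4 (0.24 log units; within the scatter) when it replaces chloro, and both steps lie within the usual scatter of repeated measurements. Compound 4 therefore cannot be told apart from either of the other two compounds, even though the step of a 2.6-fold higher number from compound 1 to compound 2 (0.42 log units; beyond the scatter) between those two lies beyond the scatter, so methoxy does not add a clearly separate level at this position. Swapping methyl for methoxy adds an oxygen and a hydrogen-bond acceptor without moving the number beyond the scatter, and no available evidence explains this result.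

The compounds shown cover only chloro, methyl and methoxy on this carbon of the shared core, so it remains open whether an amine, a carboxylic acid or a longer chain such as butoxy would move the number further than these three groups do. From the compounds shown here alone, it also remains open whether methoxy would behave the same way on another carbon of this six-membered ring.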